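The source may hold more compounds than are shown below. What is called first, only, known or untested is meant among the compounds shown, and "the series" means these compounds.

Measured compounds:
compound 1, `O=C(NOCc1ccccc1Cl)c1cn(-c2ccccc2)nc1-c1ccccc1` — 82100 nM
compound 2, `O=C(NOCc1ccccc1)c1cn(-c2ccccc2)nc1-c1ccc(F)cc1` — 217000 nM
compound 3, `O=C(NOCc1ccccc1F)c1cn(-c2ccccc2)nc1-c1ccc(F)cc1` — 147000 nM

All three were read in an ADME assay on HEK-293T cells (Homo sapiens) for antiproliferative activity, read by MTT assay, with a stated time of 48 h, in the presence of a further agent that is not named here; on this read-out lower numbers stand for higher toxicity in this test and higher numbers for lower toxicity in this test. Among the measured compounds shown here, compound 3 stands second highest of the three numbers; its nearest neighbour is compound 2, and the gap between them is the single counted step, a 1.5-fold lower number from compound 2 to compound 3 (0.17 log units; within the scatter), which is within the scatter. For the measured compounds named here, compound 1 lies on the other side of compound 3 and is also within the scatter of it, but compound 1 and compound 3 differ in two places, so no step is counted for that pair; only the two values themselves can be compared.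

Compound 4, `O=C(NOCc1ccccc1Cl)c1cn(-c2ccccc2)nc1-c1ccc(F)cc1`, has not yet been measured. It differs from compound 3 by chloro in place of fluoro on an aromatic carbon. Going by the values given here, no measured pair shows chloro in place of fluoro at that position alone. Among the compounds with values here, the only counted step, the fluoro-for-hydrogen change from compound 2 to compound 3, was within the scatter, and the values of compound 1 and compound 3 are also within the scatter of each other. A change beyond the scatter in this assay is therefore not expected; the estimated step is a 1.3-fold lower number from compound 3 to compound 4 (0.11 log units; within the scatter). Compound 4 is expected to give about 115000 nM, within 50000 nM to 260000 nM.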

Compound 4, half-maximal cytotoxic concentration: 44700 nM
The estimate for compound 4 lay 2.6-fold (0.41 log units) above the measured number, outside the stated range (below it).
By their numbers in this assay, from the lowest: compounds 4, 1, 3 and 2 (each within the scatter of the next, the first and the last beyond it).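

In this assay, among the compounds shown here, the position on the benzyl ring now shows a step beyond the scatter, which the earlier compounds did not: 2-fluorobenzyl to 2-chlorobenzyl gives a 3.3-fold lower number from compound 3 to compound 4 (0.52 log units; beyond the scatter). Chloro in place of hydrogen at the same place gives a 4.9-fold lower number from compound 2 to compound 4 (0.69 log units; beyond the scatter), so on this core the chloro compound reads as more toxic in this test than both the fluoro and the unsubstituted compounds. Fluoro in place of hydrogen stays small, at a 1.8-fold lower number from compound 1 to compound 4 (0.26 log units; within the scatter), and the two fluoro-for-hydrogen steps agree: the same change on two cores in this assay, a 1.5-fold lower number (0.17 log units; within the scatter) from compound 2 to compound 3 and a 1.8-fold lower number (0.26 log units; within the scatter) from compound 1 to compound 4, 1.2-fold (0.09 log units) apart, within the scatter of two such steps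

The compounds shown leave open whether the lower number is particular to chloro or extends to other groups at this place, such as bromo, methyl or methoxy. On these data alone, how chloro in place of fluoro reads on the core of compound 1 also remains open.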